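A few compounds are considered here, and "the series" means these few. Any claim that something is new, unique, unknown or untested is made for them only; others in the source may bear on it.

Measured so far:
compound 1, `O=C(CSc1nncnc1-c1cccc2ccccc12)Nc1ccccc1[N+](=O)[O-]`: 142000 nM
compound 2, `O=C(CSc1nncnc1-c1ccccc1Cl)Nc1ccccc1Br`: 73000 nM

In an ADME assay on MT4 cells (Homo sapiens) for cytotoxicity, read by MTT assay (a lower number here means that less compound is tolerated, a higher number that more compound is tolerated), compound 1 gives 142000 nM. Compound 1 sits at the top of the two numbers, yet its gap to compound 2 lies within the usual scatter of repeats, so the two cannot be told apart on this pair. Compound 3, `O=C(CSc1nncnc1-c1cccc2ccccc12)Nc1ccccc1Br`, remains to be measured in this assay. It differs from compound 1 thus: bromo in place of nitro on an aromatic carbon. Going by the values given here, no measured pair shows this change on the same core, so no step size is known; the expectation for the step from compound 1 to compound 3 is none beyond the scatter, as a 1.4-fold lower number from compound 1 to compound 3 (0.15 log units; within the scatter). Compound 3 is therefore estimated at 100000 nM, within 40000 nM to 250000 nM.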

Compound 3, half-maximal cytotoxic concentration: 87000 nM
Compound 3: middle estimate off by 1.1-fold (0.06 log units), on the high side; the range from low to high includes it.
By their numbers in this assay, from the lowest: compounds 2, 3 and 1 (each within the scatter of the next).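

Going by these compounds alone, compound 1 and compound 3 form the first pair that differs in one place, so this is the first direct reading of a change at this position in this assay. Going from 2-nitrophenyl to 2-bromophenyl on the shared core gives a step within the scatter (a 1.6-fold lower number from compound 1 to compound 3 (0.21 log units; within the scatter)), so the two groups cannot be told apart on this pair. No measurement at hand bears on the reason for this result.

Going by these compounds, whether an amine or a carboxylic acid at this position would also stay within the scatter remains open. Also open, on these data alone, is whether bromo in place of nitro reads the same on the core of compound 2.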